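The source may hold more compounds than are shown below. What is called first, only, known or untested is meant among the compounds shown, and "the series" means these compounds.

The series rests on a shared imide core. Compound 1 `Cc1ccc(S(=O)(=O)Nc2ccc3c(c2)C(=O)N(Cc2ccc(Cl)cc2)C3=O)cc1` gives 188000 nM in an assay on isolated protein for inhibition of lysosomal alpha-glucosidase (Rattus norvegicus), read by colorimetric assay; on this read-out lower numbers stand for stronger inhibition and higher numbers for weaker inhibition; compound 2 `Nc1ccc2c(c1)C(=O)N(CCNc1ccccc1)C2=O` gives 144000 nM, and compound 3 `O=C1c2ccccc2C(=O)N1CCNc1ccccc1` gives 184000 nM. Compound 1 carries the highest of the three numbers, but its gaps to compound 3 and to compound 2 both stay within the scatter, so no order among them can be read. Within the data shown here, the only single-point step measured, a 1.3-fold higher number from compound 2 to compound 3 (0.11 log units; within the scatter), is likewise within the scatter.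

Compound 4 `Cc1ccc(S(=O)(=O)Nc2ccc3c(c2)C(=O)N(CCNc2ccc(O)c(O)c2)C3=O)cc1` has yet to be measured. Relative to compound 1 it shows (a group of 10 heavy atoms (7 carbon, 1 nitrogen, 2 oxygen; one six-membered aromatic ring of carbon only) in place of a group of 7 heavy atoms (6 carbon, 1 chlorine; one six-membered aromatic ring of carbon only), on a saturated chain carbon bound to an amide-type nitrogen in a ring). Among the measured compounds shown here, no measured step touches this exchange directly; the nearest evidence is that compound 2 and compound 3, which carry a chain of the same kind on that nitrogen, sit within the scatter of compound 1 in this assay.

Compound 4 is therefore expected to show a 1.2-fold lower number from compound 1 to compound 4 (0.07 log units; within the scatter), that is, no change beyond the scatter. The estimate for compound 4 in this assay is 160000 nM, with a range from 50000 nM to 500000 nM.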

Compound 4, half-maximal inhibitory concentration: 28800 nM
Beside the measured number, compound 4's estimate is 5.6-fold (0.74 log units) above it, and the stated range ends above it.
By their numbers in this assay, from the lowest: compound 4; then compounds 2, 3 and 1 (each within the scatter of the next).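

In this assay, exchanging the 4-chlorophenyl for the group of 10 heavy atoms, on a saturated chain carbon bound to an amide-type nitrogen in a ring, gives a 6.5-fold lower number from compound 1 to compound 4 (0.81 log units; beyond the scatter). This is the only step shown that lies beyond the scatter, so a change at this position can move the number, which the one earlier step, at a different place on the shared core, did not show. No evidence among the data shown accounts for this step.

The exchange alters the chain, its nitrogen and the aromatic ring's hydroxyl groups all at once, so the compounds shown do not assign the step to any one of these parts. Also open, going by these compounds, is whether a carboxylic acid in place of those hydroxyl groups, or a longer chain on the ring nitrogen, would keep the lower number.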